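The source may hold more compounds than are shown below. What is called first, only, known or untested is meant among the compounds shown, and "the series" means these compounds.

Among the compounds with values here, compound 2 `CC1CCN(C(=S)SCc2ccc(C(=O)Nc3ccccc3N)cc2)CC1` gives 32.7% in a functional assay on A-375 cells (Homo sapiens) for antiproliferative activity, read by CCK-8 assay, with a stated time of 72 h, tested at 2 uM (on this read-out higher numbers stand for a stronger effect at the one concentration tested and lower numbers for a weaker effect), the higher of the two numbers so far; compound 1 `Nc1ccccc1NC(=O)c1ccc(CSC(=S)N2CCCc3ccccc32)cc1` gives 26.5% in this assay, and the two sit within the scatter of each other, as the step of a number 6.2 percentage points higher from compound 1 to compound 2 (within the scatter) shows. Compound 3 `CN(Cc1cccnc1)C(=S)SCc1ccc(C(=O)Nc2ccccc2N)cc1` is the next member: methyl((pyridin-3-yl)methyl)amino in place of 4-methylpiperidin-1-yl on a thiocarbonyl carbon. Within the data shown here, the only measured step that bears on this change is the one at the same place on the thiocarbonyl carbon, from compound 1 to compound 2, and that step, a number 6.2 percentage points higher from compound 1 to compound 2 (within the scatter), stayed within the scatter. Among the measured compounds shown here, nothing measured so far speaks for a move beyond the scatter in this assay when the group on the thiocarbonyl carbon is exchanged once more. Compound 3 is therefore expected to give 30%, within a range of 15% to 45%. The expected step of a number 2.7 percentage points lower from compound 2 to compound 3 (within the scatter) is estimated to stay within the scatter.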

Compound 3, a percentage reported as inhibition, at one concentration (the size of the read-out at that concentration, not a potency): 39.4%
The estimate for compound 3 lay 9.4 percentage points below the measured number; measured number inside the range.
By their numbers in this assay, from the lowest: compounds 1, 2 and 3 (each within the scatter of the next, the first and the last beyond it).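

Within the data shown here, on the thiocarbonyl carbon, methyl((pyridin-3-yl)methyl)amino gives the first step beyond the scatter in this assay, namely a number 12.9 percentage points higher from compound 1 to compound 3 (beyond the scatter), although this step is modest. Exchanging 4-methylpiperidin-1-yl for the same group gives a number 6.7 percentage points higher from compound 2 to compound 3 (within the scatter), so these two groups are not separated in this assay, and the only distinction so far is from 1,2,3,4-tetrahydroquinolin-1-yl. No supporting measurement is available to account for these differences.

The compounds shown leave open whether the ring nitrogen of the pyridin-3-yl group matters, which a benzyl(methyl)amino group on the thiocarbonyl carbon would test directly. Also open, from the compounds shown here alone, is whether a longer chain in place of the methyl on that amino nitrogen, or a morpholin-4-yl group on the same carbon, would give a larger step.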